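Trimming the Chloromethyl to Methyl on a Coumarin Ester

The compounds below may be only part of what the source reports. "The series", "measured", "known", "first", "only" and "open" are said of these compounds alone.

Measured compounds:
- Compound 1 `CCCC(=O)OCc1ccc2oc(=O)c(C(=O)Oc3cccc(Br)c3)cc2c1`: 88.6%
- Compound 2 `O=C(Oc1cccc(Cl)c1)c1cc2cc(CCl)ccc2oc1=O`: 98.4%
- Compound 3 `NCc1ccc2oc(=O)c(C(=O)Oc3cccc(Br)c3)cc2c1`: 88.3%

In a functional assay on HT-1080 cells (Homo sapiens), read by transwell migration, with a stated time of 24 h, tested at 0.1 uM (a lower number here means a stronger effect, a higher number a weaker effect of the compound at the concentration tested), compound 2 gives the highest number of the three, though its gap to compound 1 lies within the usual scatter and only its gap to compound 3 lies beyond it. Compound 4 `Cc1ccc2oc(=O)c(C(=O)Oc3cccc(Cl)c3)cc2c1` has not been measured; it differs from compound 2 by hydrogen in place of chloro on a saturated chain carbon bound to an aromatic carbon. Among the compounds with values here, the one measured step at that same place, a number 0.3 percentage points lower from compound 1 to compound 3 (within the scatter), changed nothing beyond the scatter, so the step in this assay from compound 2 to compound 4 is expected to be small as well, with no clear direction. The estimate for compound 4 is therefore 93%, ranging from 78% to 105%, which means an expected step of a number 5.4 percentage points lower from compound 2 to compound 4 (within the scatter).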

Compound 4, a percentage reported as activity, at one concentration (the size of the read-out at that concentration, not a potency): 81.5%
Compound 4: the middle estimate sits 11.5 percentage points above what was measured; the range from low to high includes it.
By their numbers in this assay, from the lowest: compounds 4, 3, 1 and 2 (each within the scatter of the next, the first and the last beyond it).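

In this assay the change from chloro to hydrogen on a saturated chain carbon bound to an aromatic carbon gives a number 16.9 percentage points lower from compound 2 to compound 4 (beyond the scatter), so this place can respond to a change in its group. The earlier step at this place, a number 0.3 percentage points lower from compound 1 to compound 3 (within the scatter), had not shown that. No measurement on hand explains why the two steps differ.

The compounds shown leave open how a carboxylic acid or a longer chain at this place would read, and whether chloromethyl to methyl gives a similar step on other esters of the shared core.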